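Shared-core series: the step from compound 3 to compound 4

The source may hold more compounds than are shown below. What is called first, only, known or untested is meant among the compounds shown, and "the series" means these compounds.

Compound 1 `O=C(CSc1nc(Nc2ccccc2)c2ccccc2n1)Nc1cccc([N+](=O)[O-])c1`: 33000 nM
Compound 2 `CCc1ccc(NC(=O)CSc2nc(Nc3ccccc3)c3ccccc3n2)cc1`: 33900 nM
Compound 3 `C=CC(=O)Nc1cccc(NC(=O)CSc2nc(Nc3cccc([N+](=O)[O-])c3)c3ccccc3n2)c1`: > 50000 nM

All three were run in a functional assay on MDA-MB-231 cells (Homo sapiens) for inhibition, read by MTT assay, with a stated time of 72 h; a higher number here means a weaker inhibitor, a lower number a stronger inhibitor. For the measured compounds named here, compound 1 gives 33000 nM and compound 2 gives 33900 nM, and the one measured step, a 1.0-fold higher number from compound 1 to compound 2 (0.01 log units; within the scatter), stays within the scatter. Compound 3 reaches only a limit of the assay, > 50000 nM (the limit of > 50000 nM in this assay, at which 1 of the 3 values shown sits).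

Compound 4 `C=CC(=O)Nc1cccc(NC(=O)CSc2nc(Nc3ccc(Cl)c(Cl)c3)c3ccccc3n2)c1` is still to be measured. It differs from compound 3 by 3,4-dichlorophenyl in place of 3-nitrophenyl on a nitrogen on an aromatic ring. Going by the values given here, the single measured step sits on an amide-type nitrogen, not on the nitrogen on the aromatic ring, so it gives no guide to this change, and compound 3 itself stands at a limit. The step of an at least 1.1-fold lower number from compound 3 to compound 4 (0.04 log units; that floor lies within the scatter) is therefore expected to be small and unresolved. Compound 4 is expected to give 45000 nM, between 15000 nM and 100000 nM.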

Compound 4, half-maximal inhibitory concentration: 17700 nM
Compound 4: middle estimate off by 2.5-fold (0.41 log units), on the high side; the range from low to high includes it.
By their numbers in this assay, from the lowest: compounds 4, 1 and 2 (each within the scatter of the next). At a limit, above all of these: compound 3.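

For the compounds shown here, replacing 3-nitrophenyl with 3,4-dichlorophenyl on a nitrogen on an aromatic ring gives a clear change in this assay, an at least 2.8-fold lower number from compound 3 to compound 4 (0.45 log units; beyond the scatter), so this place responds, whereas the one earlier step, on an amide-type nitrogen, stayed within the scatter. The true size of the step remains unknown, since the value for compound 3 is only a limit: the limit of > 50000 nM in this assay, at which 1 of the 4 values shown sits.

Whether both chlorines are needed remains open, as a phenyl ring carrying one chlorine is not among the compounds shown. Also open, going by these compounds, is how an amine or a carboxylic acid on this ring would compare.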